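The compounds below may be only part of what the source reports. "The series", "measured", "known", "first", "only" and "open" are said of these compounds alone.

Of the compounds shown here, three sharing one core have been measured in a functional assay on the whole organism (artery, strain albino) with Rattus norvegicus as the target, with a stated time of 300 min, at a dose of 10 mg/kg by the oral route (a lower number here means less inhibition, a higher number more inhibition at the dose given (going by the name of the read-out)), so far. Compound 2 `CC1=C(C(=O)Nc2ccc(F)cc2)C(c2ccc([N+](=O)[O-])cc2)N=C(SCc2ccccc2)N1` gives 38.5% in this assay and compound 1 `COc1ccc(C2N=C(SCc3ccc(Cl)cc3)NC(C)=C2C(=O)Nc2ccc(F)cc2)cc1OC` gives 31.3% there. Compound 3 `CC1=C(C(=O)Nc2ccc(F)cc2)C(c2ccc([N+](=O)[O-])cc2)N=C(SCc2cccc(Cl)c2)N1` stands lowest of the three in this assay with 18.5% and its nearest neighbour is compound 1 while compound 2 lies furthest, both gaps being beyond the scatter. Among the measured compounds shown here, the only measured step that reaches compound 3 is a number 20 percentage points lower from compound 2 to compound 3 (beyond the scatter) and it concerns the chlorine itself rather than where it sits.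

Compound 4 `CC1=C(C(=O)Nc2ccc(F)cc2)C(c2ccc([N+](=O)[O-])cc2)N=C(SCc2ccc(Cl)cc2)N1` differs from compound 3 in one place, 4-chlorophenyl in place of 3-chlorophenyl on a saturated chain carbon bound to a sulfur being the whole of the change. For the measured compounds named here, no measured step moves a chlorine from one position of a phenyl ring to another, so the step from compound 2 to compound 3 bears only loosely on it. Compound 1 carries the same (4-chlorobenzyl)sulfanyl group as compound 4 but a different aryl group on the core, so its value can only be noted as lying between those of compound 2 and compound 3. The account therefore expects for compound 4 a step of a number 8.5 percentage points higher from compound 3 to compound 4 (within the scatter) whose direction is uncertain. Compound 4 is estimated at 27% in this assay with a range from 12% to 42% there.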

Compound 4, a percentage reported as inhibition, in the whole organism at one dose (the size of the read-out at that dose, not a potency): 37.9%
Beside the measured number, compound 4's estimate is 10.9 percentage points below it, and the stated range covers the measured number.
By their numbers in this assay, from the lowest: compound 3; then compounds 1, 4 and 2 (each within the scatter of the next).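

In this assay the place of the chlorine counts on its own, with a number 19.4 percentage points higher from compound 3 to compound 4 (beyond the scatter) for nothing more than 4-chlorophenyl in place of 3-chlorophenyl on a saturated chain carbon bound to a sulfur. Chloro in place of hydrogen on an aromatic carbon therefore has no single reading here: a number 20 percentage points lower from compound 2 to compound 3 (beyond the scatter) goes with the 3-chlorophenyl form, while a number 0.6 percentage points lower from compound 2 to compound 4 (within the scatter) shows the 4-chlorophenyl form cannot be told apart from the unsubstituted benzyl of compound 2, so among these compounds the loss belongs to the 3-chlorophenyl group alone. With the (4-chlorobenzyl)sulfanyl group held fixed, 4-nitrophenyl in place of 3,4-dimethoxyphenyl on a saturated ring carbon gives a number 6.6 percentage points higher from compound 1 to compound 4 (within the scatter) and so shows no change that can be told from the scatter in this one pair.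

As far as these compounds go, whether a bromine, a methoxy group or a nitrile in place of that chlorine would follow the same split remains open, as does whether the split holds with the 3,4-dimethoxyphenyl group on the core. Nothing shown here gives a reason for the difference between the two chlorine places.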